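The source may report more compounds than this note shows. Statements on the series, on what has been measured and on what is new or still open speak of the compounds shown alone.

In a functional assay on Jurkat cells (Homo sapiens) (on this read-out lower numbers stand for stronger inhibition and higher numbers for weaker inhibition), compound 3 `CC(C)[C@H](NC(=O)COc1cccc2ccccc12)C(=O)N[C@@H](CC(=O)O)C(=O)COc1ccccc1F` gives > 100000 nM as its result, which is a limit of the assay and not a number. Compound 1 `CC(C)[C@H](NC(=O)COc1cccc2ccccc12)C(=O)N[C@@H](CC(=O)O)C(=O)COc1ccc(C(F)(F)F)cc1` gives > 100000 nM and this too is a limit. Compound 2 `CC(C)[C@H](NC(=O)COc1cccc2ccccc12)C(=O)N[C@@H](CC(=O)O)C(=O)COc1ccc([N+](=O)[O-])cc1` gives > 100000 nM and this is likewise a limit. The set stands at the limit of > 100000 nM in this assay, at which 3 of the 3 values shown sit, and compound 3 has no number of its own.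

Compound 4 `CC(C)[C@H](NC(=O)COc1cccc2ccccc12)C(=O)N[C@@H](CC(=O)O)C(=O)COc1ccc(F)cc1` keeps the core of compound 3 and changes one group, with 4-fluorophenyl in place of 2-fluorophenyl on an oxygen on a saturated carbon and the same atoms joined differently. For the measured compounds named here, three measured steps touch this same group, namely a step that the two limits leave unreadable from compound 1 to compound 2 and a step that the two limits leave unreadable from compound 1 to compound 3 and also a step that the two limits leave unreadable from compound 2 to compound 3 so none of them offers a size to carry over. The expectation therefore rests on compound 3 at > 100000 nM as a limit, and no direction can be drawn from it. No step beyond the scatter is expected in this assay and the estimated step is a number no higher from compound 3 to compound 4 (the limit leaves the size open) on this reading. For compound 4 the estimated value is 100000 nM with an expected range from 50000 nM to 200000 nM and a report at the limit is the likeliest outcome.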

Compound 4, half-maximal inhibitory concentration: > 100000 nM
Compound 4: only a limit was reported (the forecaster's own chance of this, stated with the estimate: 85%); the middle value sits exactly at the limit.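

In this assay compound 4 gives > 100000 nM, which is a limit of the assay and not a number. Its steps from compound 1, compound 2 and compound 3 therefore cannot be read. The compounds shown leave open how these four aromatic groups would rank against one another, as the set offers no number: the limit of > 100000 nM in this assay, at which 4 of the 4 values shown sit.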